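Removing one methyl from compound 2

A few compounds are considered here, and "the series" means these few. Any claim that something is new, unique, unknown or untested is made for them only; others in the source may bear on it.

Values in an ADME assay on MT4 cells (Homo sapiens) for cytotoxicity, read by MTT assay; on this read-out higher numbers stand for lower toxicity in this test and lower numbers for higher toxicity in this test
compound 1 `N#Cc1ccc(Nc2nc(Cc3c(F)cccc3F)cc(=O)[nH]2)cc1` gives > 2500 nM (a limit)
compound 2 `Cc1c(C(C)c2c(F)cccc2F)nc(Nc2ccc(C#N)cc2)[nH]c1=O` gives 1060 nM
compound 3 `Cc1c(C(C)c2c(F)cccc2F)nc(N(C)C)[nH]c1=O` gives > 17000 nM (a limit)

Going by the values given here, compound 2 holds the only true number here, as the other two values are limits. Compound 4 `CC(c1cc(=O)[nH]c(Nc2ccc(C#N)cc2)n1)c1c(F)cccc1F` differs from compound 2 in one place, hydrogen in place of methyl on an aromatic carbon. Among the compounds with values here, the one measured step, an at least 16-fold higher number from compound 2 to compound 3 (1.20 log units; beyond the scatter), is large but changes a different place, so it gives no direct size for this edit. Compound 1, which also has hydrogen on that carbon, reports only a limit, > 2500 nM. A modest rise in this assay is therefore expected, a 2.4-fold higher number from compound 2 to compound 4 (0.37 log units; beyond the scatter). For compound 4 the estimated value is 2500 nM, within an expected range from 800 nM to 9000 nM.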

Compound 4, half-maximal cytotoxic concentration: > 2830 nM
Compound 4 gave a limit, no number; the forecaster's own chance of this, stated with the estimate: 35%; middle value at least 1.1-fold (0.05 log units) away from the limit.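

Taking the methyl off this aromatic carbon, para to the (4-cyanophenyl)amino group, gives the first direct size for this edit in this assay: an at least 2.6-fold higher number from compound 2 to compound 4 (0.42 log units; beyond the scatter). One carbon at this position therefore separates compound 2 from the lower toxicity in this test seen for compound 4, and the value of compound 4 is a limit, so the real step may be larger. The step from compound 1 to compound 4 cannot be read, as both values are limits.

Still open, from the compounds shown here alone, is how far past its limit compound 4 lies. Also open, going by these compounds, is how an ethyl chain or an amine on this aromatic carbon would read in this assay.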